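From a Dimethylamino Group to Bromine on a Shared Core

The compounds below may be only part of what the source reports. "The series", "measured", "known", "first", "only" and "open" are said of these compounds alone.

Compound 3 `CN(C)c1nc2c(Cl)c(Cl)ccc2n1COC(CO)CO` is one of three close relatives tested in a functional assay on KB cells (Homo sapiens) for inhibition; on this read-out lower numbers stand for stronger inhibition and higher numbers for weaker inhibition. In this assay compound 3 gives > 100000 nM, which is a limit of the assay rather than a number. Compound 1 `Nc1nc2cc(Cl)c(Cl)cc2n1COC(CO)CO` carries an amino group where compound 3 has the dimethylamino group, and in this assay compound 1 gives > 100000 nM, again a limit. Compound 2 `OCC(CO)OCn1c(SCc2ccccc2)nc2cc(Cl)c(Cl)cc21` in this assay gives > 100000 nM, also a limit. For the measured compounds named here, the only single-point comparison among the measured compounds is a step that the two limits leave unreadable from compound 1 to compound 2, and because the limit of > 100000 nM in this assay, at which 3 of the 3 values shown sit, no size can be read from it. Compound 3 therefore stands at the same limit as its two relatives, with nothing to set it apart.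

Compound 4 `OCC(CO)OCn1c(Br)nc2c(Cl)c(Cl)ccc21` differs from compound 3 in one place: bromo in place of dimethylamino on an aromatic carbon. No measured step shows what such a change does in this assay, so the data give no reason to expect movement in either direction beyond the scatter. Compound 4 is therefore expected to give 100000 nM, with a range from 30000 nM to 300000 nM, most likely reported once more as a limit. The step expected is a number no higher from compound 3 to compound 4 (the limit leaves the size open), that is, no movement.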

Compound 4, half-maximal inhibitory concentration: > 100000 nM
Compound 4: no number, only a limit (the forecaster's own chance of this, stated with the estimate: 75%); the middle value lies on the limit itself.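

In this assay no step can be read from compound 3 to compound 4, because both compounds give only a limit and no number: the limit of > 100000 nM in this assay, at which 4 of the 4 values shown sit.

The compounds shown leave open whether any group on the shared core would give a readable number in this assay and so show how strongly a change in that place acts.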